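This account rests on a few compounds, and the source may have more. Where it says the series, first, only, none or still open, it means among the compounds named here.

Measured in a functional assay on HepG2 cells (Homo sapiens) for cytotoxicity, read by MTT assay, with a stated time of 48 h; a lower number here means a stronger inhibitor, a higher number a weaker inhibitor:
Compound 1 `COc1cc(-c2nnc3n2NC(c2cccs2)C(C(=O)c2ccc(C)cc2)S3)cc(OC)c1OC` gives 3700 nM.
Compound 2 `COc1cc(-c2nnc3n2NC(c2ccco2)C(C(=O)C2CC2)S3)cc(OC)c1OC` gives only a limit of the assay, > 100000 nM.
Compound 3 `COc1cc(-c2nnc3n2NC(c2cccs2)C(C(=O)c2ccc(F)cc2)S3)cc(OC)c1OC` gives 54200 nM.

Compound 2 thus stands at the limit (the limit of > 100000 nM in this assay, at which 1 of the 3 values shown sits), and no number for it is known. The unmeasured compound 4 `COc1cc(-c2nnc3n2NC(c2ccco2)C(C(=O)c2ccc([N+](=O)[O-])cc2)S3)cc(OC)c1OC` differs from compound 2 in one place: 4-nitrophenyl in place of cyclopropyl on a carbonyl carbon. For the measured compounds named here, no measured step covers this exchange; the only measured step, a 15-fold higher number from compound 1 to compound 3 (1.17 log units; beyond the scatter), alters a different group on a carbonyl carbon and was large. Because compound 2 sits at the limit (the limit of > 100000 nM in this assay, at which 1 of the 3 values shown sits), only a step toward a lower number could be seen. Compound 4 is estimated at 40000 nM, between 8000 nM and 150000 nM. The expected step is an at least 2.5-fold lower number from compound 2 to compound 4 (0.39 log units; beyond the scatter).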

Compound 4, half-maximal inhibitory concentration: 87800 nM
Estimate against measurement, compound 4: 2.2-fold (0.34 log units) below, and the stated range covers the measured number.
By their numbers in this assay, from the lowest: compound 1; then compounds 3 and 4 (each within the scatter of the next). At a limit, above all of these: compound 2.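

In this assay, the carbonyl carbon gives its first readable exchange, 4-nitrophenyl in place of cyclopropyl, with an at least 1.1-fold lower number from compound 2 to compound 4 (0.05 log units; that floor lies within the scatter). As far as these compounds go, compound 4 therefore has a number, but the floor of this step shows no gain beyond the scatter, and its true size stays unknown. For compound 2 there is only a limit of the assay, not a number: the limit of > 100000 nM in this assay, at which 1 of the 4 values shown sits.

From the compounds shown here alone, it remains open how a 4-aminophenyl or a longer alkyl chain on this carbonyl carbon would read, and whether the nitro group or the aromatic ring itself accounts for the change.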